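This account rests on a few compounds, and the source may have more. Where it says the series, first, only, none or still open, it means among the compounds named here.

Three compounds of a shared core have been examined in an ADME assay on microsomes from liver (Mus musculus, strain CD-1) for metabolic stability, read by LC-MS, with a stated time of 60 min, tested at 20 uM; on this read-out lower numbers stand for a shorter-lived compound and higher numbers for a longer-lived compound. Compound 1 `CC(Sc1nc2nn(C3COC3)cc2c(=O)n1-c1ccccc1)c1ccccc1` gives 0.783 h; compound 3 `CC(Sc1nc2nn(CC3COC3)cc2c(=O)n1-c1ccccc1)c1ccccc1` gives 0.317 h; compound 2 `CC(Sc1nc2c(cnn2C)c(=O)n1-c1ccccc1)c1cccc(F)c1` gives 0.133 h. Compound 2 stands lowest of the three: compound 3 lies nearest above it, and compound 1 furthest. Among the compounds with values here, the only step between neighbours, a 2.5-fold lower number from compound 1 to compound 3 (0.39 log units; beyond the scatter), concerns (oxetan-3-yl)methyl in place of oxetan-3-yl on an aromatic nitrogen, a part of the molecule that compound 2 and compound 4 keep unchanged.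

Compound 4 `CC(Sc1nc2c(cnn2C)c(=O)n1-c1ccccc1)c1cccnc1` differs from compound 2 in one place: pyridin-3-yl in place of 3-fluorophenyl on a saturated chain carbon bound to a saturated chain carbon and a sulfur. Within the data shown here, no measured pair shows what pyridin-3-yl in place of 3-fluorophenyl does here, so the step from compound 1 to compound 3 offers no guide, and no step beyond the scatter can be expected in this assay. The number for compound 4 is therefore expected to lie close to that of compound 2, with the estimated step of a 1.1-fold higher number from compound 2 to compound 4 (0.05 log units; within the scatter). Compound 4 is estimated at 0.15 h, within a range from 0.06 h to 0.4 h.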

Compound 4, half-life: 0.117 h
Compound 4: the middle estimate sits 1.3-fold (0.11 log units) above what was measured; measured number inside the range.
By their numbers in this assay, from the lowest: compounds 4 and 2 (each within the scatter of the next); then compound 3; then compound 1.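

In this assay the exchange of 3-fluorophenyl for pyridin-3-yl on a saturated chain carbon bound to a saturated chain carbon and a sulfur gives a 1.1-fold lower number from compound 2 to compound 4 (0.06 log units; within the scatter) and so leaves the half-life unresolved between the two compounds. Within the data shown here, no earlier step touched this place, and here a six-membered aromatic ring of carbon only and one with a single hetero atom read alike, even though the latter brings a hydrogen-bond acceptor. No evidence at hand bears on this result.

The compounds shown leave open whether a different group at this place, such as an amine, a carboxylic acid or a longer chain, would shift the half-life beyond the scatter. They also leave open whether pyridin-3-yl would read the same on the core of compound 1.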